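Compound 4: 2,6-difluoropyridin-4-yl replaces 3,5-difluorophenyl

The source may hold more compounds than are shown below. What is called first, only, known or untested is meant among the compounds shown, and "the series" means these compounds.

Measured so far:
compound 1 `O=C(O)Cc1sc(C(Cc2ccccc2)c2ccccc2)nc1-c1ccc(Cl)cc1`: 56 nM
compound 2 `O=C(O)Cc1sc(C(c2ccccc2)c2ccccc2)nc1-c1cccc(F)c1`: 2.9 nM
compound 3 `O=C(O)Cc1sc(C(c2ccc(F)cc2)c2ccc(F)cc2)nc1-c1cc(F)cc(F)c1`: 35 nM

In an in vitro assay on HEK385-7 cells for displacement of a labelled ligand from prostaglandin D2 receptor 2 (Homo sapiens) (on this read-out higher numbers stand for weaker inhibition and lower numbers for stronger inhibition), compound 3 gives 35 nM, the second highest of the three numbers. Compound 1 gives 56 nM, and its gap to compound 3 lies within the scatter, so the two cannot be told apart on this read-out. Compound 2 gives 2.9 nM, a lower number than that of compound 3 and a gap beyond the scatter; compound 2 also carries a different set of groups, so no single change accounts for it.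

Compound 4 `O=C(O)Cc1sc(C(c2ccc(F)cc2)c2ccc(F)cc2)nc1-c1cc(F)nc(F)c1` differs from compound 3 in one place: 2,6-difluoropyridin-4-yl in place of 3,5-difluorophenyl on an aromatic carbon. Among the measured compounds shown here, no measured pair shows this change, so its effect in this assay is not known from these data.

The step of a 1.4-fold higher number from compound 3 to compound 4 (0.15 log units; within the scatter) is expected to be small, most likely within the scatter, with a lean toward a higher number. For compound 4 the estimate in this assay is 50 nM, with a range from 15 nM to 170 nM.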

Compound 4, half-maximal inhibitory concentration: 5.4 nM
The estimate for compound 4 lay 9.3-fold (0.97 log units) above the measured number; the whole stated range lies above it.
By their numbers in this assay, from the lowest: compounds 2 and 4 (each within the scatter of the next); then compounds 3 and 1 (each within the scatter of the next).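

In this assay, among the compounds shown here, the position on the aromatic carbon next to the ring nitrogen responds to a change of one ring atom: 2,6-difluoropyridin-4-yl in place of 3,5-difluorophenyl gives a 6.5-fold lower number from compound 3 to compound 4 (0.81 log units; beyond the scatter) and is the first single-place step. The two groups have the same count of heavy atoms, and the entering group adds a ring nitrogen and one hydrogen-bond acceptor, so this position is not indifferent to that exchange. Nothing measured here explains the step.

Open, as far as these compounds go, is whether the step depends on the two fluorines, which a plain pyridin-4-yl or a 2,6-dichloropyridin-4-yl group would test. Also open, from the compounds shown here alone, is whether the same exchange gives a step of similar size with the large group of compound 2 on the core.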